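The source may report more compounds than this note shows. Statements on the series, on what has been measured and on what is new or still open speak of the compounds shown alone.

Compound 1 `O=C(NC(=S)Nc1ccccc1)Nc1ccc2c(c1)C(=O)C(=O)N2Cc1ccccc1` gives 2.48 in a physicochemical assay for lipophilicity, in phosphate buffer, measured as octanol-water partition (a lower number here means a more polar compound, a higher number a more lipophilic compound), second highest of the three numbers in hand. Compound 2 `Cc1ccccc1NC(=S)NC(=O)Nc1ccc2c(c1)C(=O)C(=O)N2Cc1ccccc1` gives 2.98, compound 3 `COc1ccccc1NC(=S)NC(=O)Nc1ccc2c(c1)C(=O)C(=O)N2Cc1ccccc1` gives 2.38. Within the data shown here, the steps so far concern the outer ring: a number 0.50 log units higher from compound 1 to compound 2 (beyond the scatter), a number 0.10 log units lower from compound 1 to compound 3 (within the scatter), and a number 0.60 log units lower from compound 2 to compound 3 (beyond the scatter).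

Compound 4 `O=C(NC(=S)Nc1ccccc1)Nc1ccc2c(c1)C(=O)C(=O)N2Cc1ccccc1Cl` differs from compound 1 by chloro in place of hydrogen on an aromatic carbon. Among the measured compounds shown here, no measured step puts a chloro in, and none touches the benzyl ring. The nearest guide is the single-heavy-atom addition on an aromatic carbon, which gave a number 0.50 log units higher from compound 1 to compound 2 (beyond the scatter); a step of comparable size in this assay, upward, is therefore expected. For compound 4 the estimate is a number 0.62 log units higher from compound 1 to compound 4 (beyond the scatter), giving 3.1 with a range from 2.7 to 3.5.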

Compound 4, partition coefficient: 3.18
For compound 4 the middle estimate is 0.08 log units below the measured one, within the range that was stated.
By their numbers in this assay, from the lowest: compounds 3 and 1 (each within the scatter of the next); then compounds 2 and 4 (each within the scatter of the next).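

In this assay, among these compounds, the change from benzyl to 2-chlorobenzyl gives a number 0.70 log units higher from compound 1 to compound 4 (beyond the scatter) and is the first reading on the benzyl ring, since the earlier steps all lay on the outer ring. It shows that this ring is not silent: a single chloro, ortho to a large group, moves the number beyond the scatter. No measurement in hand accounts for the size of this step. Still open, going by these compounds, is whether chloro on the outer ring gives a similar step, and how a methoxy, an amine or a carboxylic acid would read on the benzyl ring.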